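Aryl swap on a shared core and the expected cytotoxicity

A few compounds are considered here, and "the series" means these few. Any claim that something is new, unique, unknown or untested is made for them only; others in the source may bear on it.

Compound 2 `CCN(CC)c1ccc(-c2cc(Cl)cn3c([N+](=O)[O-])c(CS(=O)(=O)c4ccccc4)nc23)cc1` carries a 4-(diethylamino)phenyl group on the shared core. In an ADME assay on HepG2 cells (Homo sapiens) for cytotoxicity, read by MTT assay, with a stated time of 72 h (on this read-out lower numbers stand for higher toxicity in this test and higher numbers for lower toxicity in this test), compound 2 gives > 15600 nM, which is a limit of the assay and not a number. Its neighbour compound 1 `O=[N+]([O-])c1c(CS(=O)(=O)c2ccccc2)nc2c(-c3ccc(Cl)cc3)cc(Cl)cn12` bears a chloro group in that place. In this assay compound 1 gives > 3900 nM, again a limit rather than a number. The step from compound 1 to compound 2, a step that the two limits leave unreadable from compound 1 to compound 2, therefore cannot be read, since one value sits at the limit of > 3900 nM in this assay, at which 1 of the 2 values shown sits, and the other at the limit of > 15600 nM in this assay, at which 1 of the 2 values shown sits. Compound 3 `O=[N+]([O-])c1c(CS(=O)(=O)c2ccccc2)nc2c(-c3ccccc3C(F)(F)F)cc(Cl)cn12` differs from compound 2 by 2-(trifluoromethyl)phenyl in place of 4-(diethylamino)phenyl on an aromatic carbon. For the measured compounds named here, no measured step bears on this change: both values shown are limits, so no step size is known. Compound 2 stands at a limit with no number beneath it, and nothing shown points to compound 3 dropping into the readable range. Compound 3 is therefore expected to show low toxicity in this assay, with an estimated value of 12000 nM, between 3500 nM and 40000 nM. That estimate means an expected step of an at least 1.3-fold lower number from compound 2 to compound 3 (0.11 log units; that floor lies within the scatter).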

Compound 3, half-maximal cytotoxic concentration: 22700 nM
The estimate for compound 3 lay 1.9-fold (0.28 log units) below the measured number; measured number inside the range.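

In this assay, the number for compound 3 yields no readable step from compound 1 or from compound 2, since each of those two compounds stands at a limit of the assay and not at a number. Going by these compounds, whether either of them truly differs from compound 3, and by how much, stays open.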